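The compounds below may be only part of what the source reports. "The series", "measured", "known", "first", "only" and "open" are said of these compounds alone.

Three compounds have so far been tested in a functional assay on KB cells (Homo sapiens) for inhibition, read by MTT assay, with a stated time of 24 h, tested at 10 ug/mL; on this read-out lower numbers stand for less inhibition of growth and higher numbers for more inhibition of growth at the one concentration tested:

compound 1 `O=C(CCCCC(S)CCS)Nc1ccccc1` gave 8.62%
compound 2 `O=C(CCCCC(S)CCS)Nc1ccc(Cl)cc1` gave 18.2%
compound 3 `O=C(CCCCC(S)CCS)Nc1ccccn1` gave 0.28%

Compound 4 `O=C(CCCCC(S)CCS)Nc1ccc(Cl)cn1` has not yet been tested in this assay. It differs from compound 3 by chloro in place of hydrogen on an aromatic carbon. The same kind of change is already known between two measured compounds, (chloro in place of hydrogen on an aromatic carbon), where the step was a number 9.6 percentage points higher from compound 1 to compound 2 (within the scatter). The two cores differ by pyridin-2-yl in place of phenyl on an amide-type nitrogen, with a step of a number 8.3 percentage points lower from compound 1 to compound 3 (within the scatter). The place of the new chloro is not quite the same: in compound 2 it sits on a six-membered aromatic ring of carbon only, in compound 4 on a six-membered aromatic ring with 1 nitrogen, two atoms from the ring nitrogen; in both it is para to a large group. Because a number 9.6 percentage points higher from compound 1 to compound 2 (within the scatter) lies within the scatter, a similarly small step is expected for compound 4, a number 7.7 percentage points higher from compound 3 to compound 4 (within the scatter). Compound 4 is thus expected to give about 8% in this assay, likely between 0% and 22%.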

Compound 4, percent growth inhibition at one concentration: 21.6%
The estimate for compound 4 lay 13.6 percentage points below the measured number, and the stated range covers the measured number.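

In this assay chloro in place of hydrogen on an aromatic carbon gave a number 21.3 percentage points higher from compound 3 to compound 4 (beyond the scatter) and so moved the number in the same direction on both cores. Set beside the earlier case, the two steps cannot be told apart: the same change on two cores in this assay, a number 9.6 percentage points higher (within the scatter) from compound 1 to compound 2 and a number 21.3 percentage points higher (beyond the scatter) from compound 3 to compound 4, 11.7 percentage points apart, within the scatter of two such steps. This supports carrying the change between these two cores, but only the second step stands clear of the scatter, and a single pair of cores shows neither that the size of the step holds in general nor that the change would work on any other core.

The compounds shown leave open whether bromo, methoxy or an amine on the same aromatic carbon would behave like chloro. They also leave open what chloro would do elsewhere on the ring.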